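Nitrone series: tert-butyl for benzyl on a second core

The source may hold more compounds than are shown below. What is called first, only, known or untested is meant among the compounds shown, and "the series" means these compounds.

Compound 1 `COc1ccc(-n2cc(/C=[N+](\[O-])Cc3ccccc3)nn2)cc1` and compound 3 `COc1ccc(-n2cc(/C=[N+](\[O-])C(C)(C)C)nn2)cc1` share one core; compound 2 `CCCCCCCCn1cc(/C=[N+](\[O-])Cc2ccccc2)nn1` carries another, and the difference between the two cores is not broken down here. In a functional assay on COLO 205 cells (Homo sapiens) for inhibition, read by MTT assay, with a stated time of 24 h (on this read-out higher numbers stand for weaker inhibition and lower numbers for stronger inhibition), compound 1 reaches only the assay limit > 100000 nM. In this assay compound 3 gives 19800 nM. The change is tert-butyl in place of benzyl on a double-bonded nitrogen, and it produces an at least 5.0-fold lower number from compound 1 to compound 3 (0.70 log units; beyond the scatter), a size that rests on the limit of > 100000 nM in this assay, at which 2 of the 3 values shown sit, and is therefore itself a floor. Compound 2 likewise reaches only the limit > 100000 nM in this assay. Compound 4 `CCCCCCCCn1cc(/C=[N+](\[O-])C(C)(C)C)nn1` is not yet measured; it arises from compound 2 by tert-butyl in place of benzyl on a double-bonded nitrogen, the same change at the same place. The step is expected to be an at least 3.3-fold lower number from compound 2 to compound 4 (0.52 log units; beyond the scatter), resting on the measured step of an at least 5.0-fold lower number from compound 1 to compound 3 (0.70 log units; beyond the scatter). Compound 4 is estimated to give 30000 nM in this assay, expected between 8000 nM and 100000 nM.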

Compound 4, half-maximal inhibitory concentration: 30800 nM
Compound 4: middle estimate off by 1.0-fold (0.01 log units), on the low side; measured number inside the range.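

In this assay, tert-butyl in place of benzyl on a double-bonded nitrogen gives a step in the same direction on the second core, namely an at least 3.2-fold lower number from compound 2 to compound 4 (0.51 log units; beyond the scatter). The direction of the change therefore carries from the core of compound 1 to the core of compound 2, but its size on each core stays unsettled: the same change on two cores in this assay, an at least 5.0-fold lower number (0.70 log units; beyond the scatter) from compound 1 to compound 3 and an at least 3.2-fold lower number (0.51 log units; beyond the scatter) from compound 2 to compound 4; the limit leaves it open whether they differ. Both steps are floors rather than measured sizes, as each starts from a compound that reaches only a limit: the limit of > 100000 nM in this assay, at which 2 of the 4 values shown sit.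

Still open, going by these compounds, is whether other groups at this place, such as isopropyl, cyclohexyl or a longer chain, would follow tert-butyl. The same holds for a group carrying an amine or a carboxylic acid.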